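Chloro for Methyl on the Anilide of Compound 2

The source may report more compounds than this note shows. Statements on the series, on what has been measured and on what is new or still open speak of the compounds shown alone.

Of the compounds shown here, two from this series have been tested for antiproliferative activity in a functional assay on the whole organism (Ehrlich cells, Mus musculus) for antiproliferative activity, with a stated time of 24 h, at a dose of 0.2 mmol/kg by the intraperitoneal route; on this read-out lower numbers stand for less inhibition and higher numbers for more inhibition at the one dose given (going by the name of the read-out). Compound 1 `Nc1ccccc1NC(=O)CCCNCC(=O)Nc1ccc(Cl)cc1` gives 72.7% in this assay, and compound 2 `Cc1ccc(NC(=O)CNc2ccc(C(=O)Nc3ccccc3N)cc2)cc1` gives 43.3%. Compound 2 therefore stands lowest of the two numbers, with its nearest neighbour, compound 1, sitting a good way higher, a gap beyond the usual scatter of this measurement. The two structures differ in more than one place, so the gap cannot be tied to any single change.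

Compound 3 `Nc1ccccc1NC(=O)c1ccc(NCC(=O)Nc2ccc(Cl)cc2)cc1` has not yet been measured in this assay. It differs from compound 2 in one place only: chloro in place of methyl on an aromatic carbon. Within the data shown here, no step between measured compounds isolates this change, so its size is not known from the data. Compound 1, which gives 72.7%, carries a chloro group on its anilide, but its other differences from compound 2 leave that observation only suggestive. On this basis a modest rise, not clearly beyond the scatter, is expected from compound 2 to compound 3, a number 6.7 percentage points higher from compound 2 to compound 3 (within the scatter). Compound 3 is estimated to give 50% in this assay, within a range from 32% to 68%.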

Compound 3, a percentage reported as inhibition, in the whole organism at one dose (the size of the read-out at that dose, not a potency): 79.4%
Compound 3: middle estimate off by 29.4 percentage points, on the low side; measured number above the stated range.
By their numbers in this assay, from the lowest: compound 2; then compounds 1 and 3 (each within the scatter of the next).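

Read in this assay, chloro in place of methyl on this aromatic carbon, para to a large group, gives a number 36.1 percentage points higher from compound 2 to compound 3 (beyond the scatter), the first reading of this change that is not mixed with differences elsewhere in the structure. The exchange is small on paper: one heavy atom leaves and one enters, neither group carries a hydrogen-bond donor or acceptor, neither carries a net charge, and the rest of the molecule stays the same, so this one position on the anilide is shown to matter strongly for the read-out at the dose given. No measurement at hand shows what lies behind the size of this step.

As far as these compounds go, what a fluoro group, a methoxy group or a plain hydrogen would give at this position remains open, as does the outcome of moving the chloro elsewhere on the same ring. The step also rests on a single pair at a single dose, so it tells nothing about potency, nor whether the same exchange would count for as much on the core of compound 1.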